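The source may hold more compounds than are shown below. What is called first, only, known or untested is meant among the compounds shown, and "the series" means these compounds.

Working notes on the series. Compound 2 `O=C(O)CCc1ccc(NCc2ccccc2)cc1` stands highest of the three measured compounds in a functional assay on CHO cells for agonist activity at Free fatty acid receptor 1 (Homo sapiens), read by reporter gene assay (on this read-out lower numbers stand for smaller maximal responses and higher numbers for larger maximal responses), giving 144%. Compound 1 `O=C(O)CCc1ccc(NCc2ccc(Cl)cc2)cc1` gives 111% in this assay, and compound 3 `O=C(O)CCc1ccc(NCc2ccc(O)cc2)cc1` gives 37%. The steps among them are all beyond the scatter: a number 33 percentage points higher from compound 1 to compound 2 (beyond the scatter), a number 74 percentage points lower from compound 1 to compound 3 (beyond the scatter) and a number 107 percentage points lower from compound 2 to compound 3 (beyond the scatter), so every change made so far at the aromatic carbon of the phenyl has shifted the maximal response by a large amount, and the hydroxy, which adds a hydrogen-bond donor and acceptor, lowered it most.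

Compound 4 `O=C(O)CCc1ccc(NCc2ncc[nH]2)cc1` differs from compound 2 by 1H-imidazol-2-yl in place of phenyl on a saturated chain carbon bound to a nitrogen on an aromatic ring. Going by the values given here, no measured step exchanges the whole phenyl, so none bears on this change directly; the nearest is the step of a number 107 percentage points lower from compound 2 to compound 3 (beyond the scatter), in which a ring carrying a hydrogen-bond donor and acceptor replaced a ring without them, and the 1H-imidazol-2-yl also brings one donor and one acceptor. On that basis a large downward step from compound 2 to compound 4 is expected in this assay, with wide uncertainty because the ring itself changes. The estimated step is a number 79 percentage points lower from compound 2 to compound 4 (beyond the scatter). Compound 4 is expected to give about 65%, in the range from 25% to 120%.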

Compound 4, largest response reached (reported as percent of maximum), in percent of the reference or control that the assay uses: 4%
Compound 4: middle estimate off by 61 percentage points, on the high side, and the stated range ends above it.
By their numbers in this assay, from the lowest: compound 4; then compound 3; then compound 1; then compound 2.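

The step of a number 140 percentage points lower from compound 2 to compound 4 (beyond the scatter) exceeds every step among the compounds that keep the phenyl, the largest of which is a number 107 percentage points lower from compound 2 to compound 3 (beyond the scatter), so exchanging the whole ring at this place lowers the maximal response further than any change made on the phenyl so far. In this assay compound 4 gives 4%, which shows that with 1H-imidazol-2-yl on this saturated chain carbon bound to a nitrogen on an aromatic ring, very little of the response seen with phenyl remains. No measurement at hand explains the size of this drop, and this single exchange changes the ring size and the hetero atoms together.

Going by these compounds, it remains open whether a pyridin-2-yl or a thiophen-2-yl at the same place would stay close to compound 2 or fall towards compound 4, which would help separate the ring size from the ring nitrogens. On these data alone, it also remains open whether 1-methyl-1H-imidazol-2-yl, which has a methyl group on the ring nitrogen that carries the hydrogen in compound 4, would give a response different from that of compound 4.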